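Aryl swap on the core: expectation for compound 4

The source may hold more compounds than are shown below. What is called first, only, known or untested is meant among the compounds shown, and "the series" means these compounds.

Working notes on the series built on the core of compound 1 `CCOC(=O)C12C(=O)OCC=C1COC2c1ccccc1F`. In a functional assay on QGY cells (Homo sapiens) for cytotoxicity, read by MTT assay (on this read-out lower numbers stand for stronger inhibition and higher numbers for weaker inhibition), compound 1 gives only a limit, > 1000000 nM. Compound 2 `CCOC(=O)C12C(=O)OCC=C1COC2c1ccc(OC)cc1` likewise gives only a limit in this assay, > 1000000 nM. Compound 3 `CCOC(=O)C12C(=O)OCC=C1COC2c1ccc(OC)c(OC)c1` also gives only a limit in this assay, > 1000000 nM. Compound 1 therefore stands nowhere in particular among the numbers shown: all three values sit at the same limit (the limit of > 1000000 nM in this assay, at which 3 of the 3 values shown sit), and the one comparable step, a step that the two limits leave unreadable from compound 2 to compound 3, is unreadable, both ends being limits. Compound 4 `CCOC(=O)C12C(=O)OCC=C1COC2c1ccccn1` differs from compound 1 in one place: pyridin-2-yl in place of 2-fluorophenyl on a saturated ring carbon. Within the data shown here, no measured step bears on this swap; the only step touching the aromatic substituent, methoxy in place of hydrogen, is unreadable, and no other aryl change has been measured. With every value at the limit, the expected step from compound 1 to compound 4 in this assay is no readable change, a number no higher from compound 1 to compound 4 (the limit leaves the size open). Compound 4 is accordingly estimated at 1000000 nM in this assay, within 200000 nM to 5000000 nM, and is most likely to be reported again only as a limit.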

Compound 4, half-maximal inhibitory concentration: > 1000000 nM
Compound 4 was reported as a limit (the forecaster's own chance of this, stated with the estimate: 85%); the middle value sits exactly at the limit.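

No new step can be read between compound 1 and compound 4, since both are reported only as limits in this assay, as is every compound shown: the limit of > 1000000 nM in this assay, at which 4 of the 4 values shown sit. The compounds shown leave open whether any aryl group on the shared core gives a measurable value in this assay.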